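One amino group added to compound 1

The compounds below may be only part of what the source reports. "The series", "measured", "known", "first", "only" and "open" are said of these compounds alone.

Measured in a functional assay on A549 cells (Homo sapiens) for inhibition (on this read-out higher numbers stand for weaker inhibition and lower numbers for stronger inhibition), so far:
Compound 1 `COc1ccc(/C=C/c2ccc3ccccc3c2)cc1` gives > 5000 nM as a limit
Compound 2 `FC(F)(F)c1ccc(/C=C/c2ccc3ccccc3c2)cc1` gives > 5000 nM as a limit
Compound 3 `CN(C)c1ccc(/C=C/c2ccc3ccccc3c2)cc1` gives 3660 nM as a number

Compound 1 stands at the limit of > 5000 nM in this assay, at which 2 of the 3 values shown sit, and so has no exact number of its own. The next compound to be tested is compound 4 `COc1ccc(/C=C/c2ccc3ccccc3c2)cc1N` which keeps the core of compound 1 and all of its groups. Among the measured compounds shown here, the only change is amino in place of hydrogen on an aromatic carbon so an amino group takes the place of a hydrogen on the ring that carries the methoxy group.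

For the measured compounds named here, no measured step adds a group in this way, so the guidance is indirect. The step that the two limits leave unreadable from compound 1 to compound 2 tells nothing about size. The nearest guide is an at least 1.3-fold lower number from compound 1 to compound 3 (0.13 log units; that floor lies within the scatter) which also brings a nitrogen group onto that ring, but its floor lies within the scatter. The step of an at least 1.3-fold lower number from compound 2 to compound 3 (0.13 log units; that floor lies within the scatter) is no larger. Going by the values given here, compound 3 at 3660 nM is the only one with a readable number, and that suggests a modest move toward lower numbers at best. The estimated step is an at least 1.4-fold lower number from compound 1 to compound 4 (0.15 log units; that floor lies within the scatter) and it may not clear the scatter. For compound 4 the expected value is 3500 nM with an estimated range from 800 nM to 10000 nM in this assay and a result at the limit remains possible.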

Compound 4, half-maximal inhibitory concentration: 1820 nM
The estimate for compound 4 lay 1.9-fold (0.28 log units) above the measured number, within the range that was stated.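

In this assay, an amino group placed ortho to the methoxy group, where compound 1 carries only a hydrogen, gives an at least 2.7-fold lower number from compound 1 to compound 4 (0.43 log units; beyond the scatter) and so moves the read-out clearly toward stronger inhibition. Among the steps shown, this is the only one that reaches beyond the scatter, whereas the earlier exchanges of the methoxy group itself gave steps that either cannot be read or have floors within the scatter, so a new group on this carbon of the ring has an effect that replacing the methoxy group did not show. From the compounds shown here alone, the true size of the step remains unknown, and the figure is only a floor, because compound 1 has no exact number of its own: the limit of > 5000 nM in this assay, at which 2 of the 4 values shown sit.

Going by these compounds, it remains open whether the amino group is needed at this carbon or whether another group would serve as well, such as a hydroxyl group, a methylamino group or an acetamide. Also open, on these data alone, is whether an amino group would have the same effect on another carbon of this ring, or alongside a longer chain such as ethoxy in place of the methoxy group.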